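Working notes: compound 2 to compound 3 in receptor binding

The source may hold more compounds than are shown below. What is called first, only, known or untested is meant among the compounds shown, and "the series" means these compounds.

Among the compounds with values here, in an assay for displacement of a labelled ligand from Adrenergic receptor alpha-1 (Homo sapiens) (a higher number here means a weaker inhibitor, a lower number a stronger inhibitor), compound 1 `CCOc1ccccc1N1CCN(CCCCn2ncc(=O)n(C)c2=O)CC1` gives 1.8 nM and compound 2 `Cn1c(=O)cnn(CCCCN2CCN(c3ccccc3F)CC2)c1=O` gives 9.73 nM, the higher of the two numbers; the single measured step, a 5.4-fold higher number from compound 1 to compound 2 (0.73 log units; beyond the scatter), is a fluoro in place of ethoxy on an aromatic carbon. Compound 3 `Cn1c(=O)cnn(CCCCN2CCN(c3cccc(F)n3)CC2)c1=O` differs from compound 2 by 6-fluoropyridin-2-yl in place of 2-fluorophenyl on an amine nitrogen in a ring. No measured step alters the ring on the amine nitrogen in a ring itself, so nothing among these two compounds bears on this change, and no step beyond the scatter is expected in this assay. For compound 3 a value of 12 nM is estimated, within 4 nM to 40 nM, which is expected to be the step of a 1.2-fold higher number from compound 2 to compound 3 (0.09 log units; within the scatter).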

Compound 3, inhibition constant: > 10000 nM
Compound 3: a limit, no number (the forecaster's own chance of this, stated with the estimate: 2%); middle value at least 830-fold (2.92 log units) away from the limit.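

In this assay, the aromatic group on the amine nitrogen in a ring proves far less tolerant than the earlier fluoro-for-ethoxy change suggested: 6-fluoropyridin-2-yl in place of 2-fluorophenyl gives an at least 1000-fold higher number from compound 2 to compound 3 (3.01 log units; beyond the scatter). The same group in place of 2-ethoxyphenyl gives an at least 5500-fold higher number from compound 1 to compound 3 (3.74 log units; beyond the scatter). Compound 3 gives a limit of the assay, not a number: the limit of > 10000 nM in this assay, at which 1 of the 3 values shown sits.

Going by these compounds, whether the loss follows the ring nitrogen or the placing of the fluorine stays open. Unsubstituted pyridin-2-yl would help separate the two, and the full size of both steps remains unknown.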